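Cytotoxicity notes on a para-substituted aryl series

The source may hold more compounds than are shown below. What is called first, only, known or untested is meant among the compounds shown, and "the series" means these compounds.

Measured compounds:
compound 1 `CCOC(=O)C12C(=O)OCC=C1COC2c1ccc(Cl)cc1` — in a functional assay on QGY cells (Homo sapiens) for cytotoxicity, read by MTT assay (on this read-out lower numbers stand for stronger inhibition and higher numbers for weaker inhibition), compound 1 gives > 1000000 nM, a limit of this assay.
compound 2 `CCOC(=O)C12C(=O)OCC=C1COC2c1ccc(N(C)C)cc1` — in this assay compound 2 gives > 1000000 nM, likewise a limit.

Compound 2 therefore stands only at the limit; both values shown sit there (the limit of > 1000000 nM in this assay, at which 2 of the 2 values shown sit), and the step that the two limits leave unreadable from compound 1 to compound 2 cannot be read. The next member, compound 3 `CCOC(=O)C12C(=O)OCC=C1COC2c1ccc([N+](=O)[O-])cc1`, carries nitro in place of dimethylamino on an aromatic carbon. Among the measured compounds shown here, no measured step bears on this change, and the only step known gives no size. The expectation for compound 3 is accordingly a step that the limit leaves unreadable from compound 2 to compound 3, most likely again a limit. Compound 3 is estimated at 2000000 nM, with a range from 300000 nM to 10000000 nM.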

Compound 3, half-maximal inhibitory concentration: > 1000000 nM
Compound 3: no number, only a limit; the forecaster's own chance of this, stated with the estimate: 85%; the middle value lies beyond the limit too.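

No step can be read among compound 1, compound 2 and compound 3, because all three stand only at a limit: the limit of > 1000000 nM in this assay, at which 3 of the 3 values shown sit.

The compounds shown leave open whether the chloro, dimethylamino and nitro groups differ at all in this assay.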